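The source may hold more compounds than are shown below. What is called first, only, known or untested is meant among the compounds shown, and "the series" means these compounds.

Compounds measured:
- compound 1, `COc1ccc(Nc2nnnn2-c2ccc(Br)cc2)cc1`: 103000 nM
- compound 2, `COc1ccc(-n2nnnc2Nc2ccccc2Cl)cc1`: 134000 nM

In an ADME assay on HaCaT cells (Homo sapiens) for cytotoxicity, read by MTT assay, with a stated time of 72 h (a higher number here means a weaker inhibitor, a lower number a stronger inhibitor), compound 1 gives 103000 nM. In this assay compound 2 gives 134000 nM, and the two numbers lie within the usual scatter of each other, so compound 1 merely has the lower of the two numbers without any real separation from compound 2. Compound 3, `COc1ccc(Nc2nnnn2-c2cccc(Br)c2)cc1`, has not yet been measured in this assay. It differs from compound 1 as follows: 3-bromophenyl in place of 4-bromophenyl on an aromatic nitrogen. No measured pair shows what such a change does in this assay, so there is no shown step to lean on. Given the change, the step from compound 1 to compound 3 is expected to be small, with neither direction favoured and nothing beyond the scatter, as a 1.1-fold higher number from compound 1 to compound 3 (0.03 log units; within the scatter). Compound 3 is therefore estimated at 110000 nM in this assay, with a range from 50000 nM to 250000 nM.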

Compound 3, half-maximal inhibitory concentration: 107000 nM
Beside the measured number, compound 3's estimate is 1.0-fold (0.01 log units) above it; the measured number falls inside the stated range.
By their numbers in this assay, from the lowest: compounds 1, 3 and 2 (each within the scatter of the next).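

With 3-bromophenyl in place of 4-bromophenyl on an aromatic nitrogen of the shared core, this assay gives a 1.0-fold higher number from compound 1 to compound 3 (0.02 log units; within the scatter). Going by these compounds alone, this is the first pair here that differs in one place, and it shows that this exchange of bromophenyl groups produces no separation between the two compounds in this read-out, so at this position the two groups cannot be told apart. Nothing available explains this result or shows what lies behind it.

The compounds shown leave open whether the number would respond to a different kind of group on this aromatic nitrogen, such as a phenyl carrying a carboxylic acid or an amine instead of bromine. They also leave open whether a longer chain in place of the methoxy group would separate from compound 1.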